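A few compounds are considered here, and "the series" means these few. Any claim that something is new, unique, unknown or untested is made for them only; others in the source may bear on it.

Compound 1 `CCCCC(=O)N(Cc1ccc(OC)c(O)c1)c1cc(OC)c(OC)c(OC)c1` gives 170 nM
Compound 2 `C/C=C/C=C/C(=O)N(Cc1ccc(OC)c(O)c1)c1cc(OC)c(OC)c(OC)c1` gives 180 nM

Going by the values given here, in a functional assay on HCT-116 cells (Homo sapiens) for inhibition, read by MTT assay, with a stated time of 48 h (a lower number here means a stronger inhibitor, a higher number a weaker inhibitor), these two compounds differ only in the chain on the carbonyl carbon, and compound 2 stands within the scatter of compound 1, the only other compound measured so far. Compound 3 `CC/C=C/C(=O)N(Cc1ccc(OC)c(O)c1)c1cc(OC)c(OC)c(OC)c1` has not yet been measured. It keeps the shared core of compound 2 and alters the end of that chain. The change is ethyl in place of prop-1-en-1-yl on a double-bonded chain carbon bound to a double-bonded chain carbon and its place is on a double-bonded chain carbon bound to a double-bonded chain carbon, so that penta-1,3-dien-1-yl becomes but-1-en-1-yl.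

Among the compounds with values here, one measured step bears on this change: a 1.1-fold higher number from compound 1 to compound 2 (0.02 log units; within the scatter) when penta-1,3-dien-1-yl took the place of butyl on the carbonyl carbon. Within the data shown here, this is thin evidence, as no measured compound carries the but-1-en-1-yl chain. Even so, replacing one chain with another on this carbonyl has so far left the number within the scatter, and the same is expected here in this assay with no clear direction. The expected step is a 1.1-fold lower number from compound 2 to compound 3 (0.02 log units; within the scatter) and it is not expected to exceed the scatter. Compound 3 is estimated at 170 nM (90 nM to 330 nM).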

Compound 3, half-maximal inhibitory concentration: 63 nM
The estimate for compound 3 lay 2.7-fold (0.43 log units) above the measured number; the measured number lies below the stated range.
By their numbers in this assay, from the lowest: compound 3; then compounds 1 and 2 (each within the scatter of the next).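

In this assay, the chain on the carbonyl carbon can change the number after all, which the near-identical results for compound 1 and compound 2 had not shown. Ethyl in place of prop-1-en-1-yl on a double-bonded chain carbon bound to a double-bonded chain carbon gives a modest gain (a 2.9-fold lower number from compound 2 to compound 3 (0.46 log units; beyond the scatter)), and but-1-en-1-yl in place of butyl on a carbonyl carbon gives a similar one (a 2.7-fold lower number from compound 1 to compound 3 (0.43 log units; beyond the scatter)), so compound 3 is the strongest inhibitor of the three, reached from either of two different chains. Nothing available here explains why but-1-en-1-yl stands apart from the other two chains.

Going by these compounds, with only three chains to compare, it remains open whether the gain is specific to but-1-en-1-yl or would extend to close relatives such as pent-1-en-1-yl, a longer chain with a single double bond, or prop-1-en-1-yl, a shorter one. Also open, on these data alone, is how this position would respond to a chain ending in an amine or a carboxylic acid, or to a phenyl ring in place of the chain.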